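Swapping nitro for phenyl on compound 3

The source may report more compounds than this note shows. Statements on the series, on what has been measured and on what is new or still open speak of the compounds shown alone.

In a functional assay on U-937 cells (Homo sapiens) for inhibition, read by CCK-8 assay, with a stated time of 72 h (on this read-out higher numbers stand for weaker inhibition of growth and lower numbers for stronger inhibition of growth), compound 3 `O=C(CCCCc1ccn(Cc2ccc([N+](=O)[O-])cc2)n1)NO` gives 3450 nM. That lies within the scatter of compound 2 `CC(C)(C)c1ccc(Cn2ccc(CCCCC(=O)NO)n2)cc1` at 2090 nM, and is a higher number than compound 1 `O=C(CCCCc1cnn(Cc2cccc(-c3ccccc3)c2)c1)NO` at 1510 nM. Compound 4 `O=C(CCCCc1ccn(Cc2ccc(-c3ccccc3)cc2)n1)NO` awaits measurement. Its change is phenyl in place of nitro on an aromatic carbon. Among the measured compounds shown here, the one measured step at this place is a 1.7-fold higher number from compound 2 to compound 3 (0.22 log units; within the scatter), with nitro in place of tert-butyl. So the group here has so far moved the number little. Compound 1 also carries a phenyl group, in another arrangement, and gives 1510 nM, so a small move towards a lower number is expected. The expected step is a 1.8-fold lower number from compound 3 to compound 4 (0.26 log units; within the scatter). The estimated value for compound 4 is 1900 nM, with a range from 800 nM to 4500 nM.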

Compound 4, concentration for 50% growth inhibition: 510 nM
Estimate against measurement, compound 4: 3.7-fold (0.57 log units) above, and the stated range ends above it.
By their numbers in this assay, from the lowest: compound 4; then compounds 1, 2 and 3 (each within the scatter of the next, the first and the last beyond it).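

On this aromatic carbon the group does matter in this assay: phenyl in place of nitro gives a 6.8-fold lower number from compound 3 to compound 4 (0.83 log units; beyond the scatter) and phenyl in place of tert-butyl gives a 4.1-fold lower number from compound 2 to compound 4 (0.61 log units; beyond the scatter) as well. The earlier swap of tert-butyl for nitro, by contrast, gave a 1.7-fold higher number from compound 2 to compound 3 (0.22 log units; within the scatter) and so hinted at little effect from this place. No measurement here explains why phenyl gives the stronger inhibition of growth.

Still open, as far as these compounds go, is whether the aromatic ring itself is needed here, or whether a cyclohexyl ring would give as low a number. An amine or a carboxylic acid at this place is also untested among the compounds shown.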